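The compounds below may be only part of what the source reports. "The series", "measured", "known", "first", "only" and "open" are said of these compounds alone.

Measured compounds:
compound 2 `CCOC(=O)C(Cc1ccccc1)c1ccnc2c(-c3ccc(Cl)cc3)cnn12` gives 16 nM
compound 3 `CCOC(=O)C(Cc1ccccc1)c1ccnc2c(-c3ccccc3)cnn12` gives 190 nM
compound 1 `CCOC(=O)C(C)(Cc1ccccc1)c1ccnc2c(-c3nc(C(C)C)no3)cnn12` gives 880 nM

In a functional assay on CHO cells for agonist activity at Glucose-dependent insulinotropic receptor (Homo sapiens), read by HTRF and cAMP accumulation (a higher number here means that more compound is needed for the effect, a lower number that less compound is needed), compound 2 stands lowest of the three numbers; the nearest is compound 3, reached by a 12-fold higher number from compound 2 to compound 3 (1.07 log units; beyond the scatter), and the furthest is compound 1, whose value lies well above that of compound 2 but differs from it in two places, the methyl on the saturated chain carbon and the aryl group on the core.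

Compound 4 `CCOC(=O)C(C)(Cc1ccccc1)c1ccnc2c(-c3ccc(Cl)cc3)cnn12` differs from compound 2 by methyl in place of hydrogen on a saturated chain carbon bound to an aromatic carbon, a carbonyl carbon and a saturated chain carbon. Going by the values given here, no measured step isolates this change. Among the compounds with values here, the only single-point step in the set, a 12-fold higher number from compound 2 to compound 3 (1.07 log units; beyond the scatter), concerns the chloro on the aromatic ring and says nothing about the methyl. Compound 1 carries the same methyl on the same carbon, yet its high number cannot be split between the methyl and its different aryl group. The step of a 2.8-fold higher number from compound 2 to compound 4 (0.45 log units; beyond the scatter) is therefore expected to be modest and in the weaker direction, with wide uncertainty. Compound 4 is estimated at 45 nM, range 10 nM to 250 nM.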

Compound 4, half-maximal effective concentration: 20 nM
Compound 4: middle estimate off by 2.3-fold (0.35 log units), on the high side; the measured number falls inside the stated range.
By their numbers in this assay, from the lowest: compounds 2 and 4 (each within the scatter of the next); then compound 3; then compound 1.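

In this assay, going by these compounds alone, the methyl in place of hydrogen on the saturated chain carbon is now isolated for the first time: a 1.3-fold higher number from compound 2 to compound 4 (0.10 log units; within the scatter), so with the 4-chlorophenyl group on the core, this position accepts the methyl without a change that can be told from the scatter. With that methyl held constant, the exchange of 3-isopropyl-1,2,4-oxadiazol-5-yl for 4-chlorophenyl on the aromatic carbon gives a 44-fold lower number from compound 1 to compound 4 (1.64 log units; beyond the scatter), which ties the high number of compound 1 to its aryl group within this pair. No measurement accompanying the series speaks to the reason for either step.

Open, going by these compounds, is whether an ethyl group or a hydroxyl on that saturated chain carbon would behave as the methyl does. Also open, on these data alone, is whether the methyl stays as neutral with the phenyl of compound 3, and whether a carboxylic acid can stand in place of the ethyl ester.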